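The compounds below may be only part of what the source reports. "The series", "measured", "known", "first", "only" and "open" are said of these compounds alone.

Of the compounds shown here, three of one shared core have been tested in a toxicity assay on HepG2 2.2.15 cells (Homo sapiens) for cytotoxicity, read by CCK-8 assay, with a stated time of 8 days; on this read-out higher numbers stand for lower toxicity in this test and lower numbers for higher toxicity in this test. Compound 1, `CC(C)Cc1nn(-c2cccc(F)c2)cc1C(=O)NCc1ccc(F)cc1`, reaches only the limit of the test, > 100000 nM, which is a boundary rather than a number; it matches (the limit of > 100000 nM in this assay, at which 1 of the 3 values shown sits). Compound 2, `CCOC(=O)c1cn(-c2cccc(OC)c2)nc1CC(C)C`, gives 70500 nM. Compound 3, `CC(C)Cc1nn(-c2nccs2)cc1C(=O)NCc1ccc(F)cc1F`, gives 83600 nM, a number that sits within the usual scatter of what compound 2 shows, so the two cannot be ranked against each other.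

Compound 4, `CC(C)Cc1nn(-c2nccs2)cc1C(=O)NCc1ccc(N)cc1`, is not yet measured. It differs from compound 3 in one place: 4-aminophenyl in place of 2,4-difluorophenyl on a saturated chain carbon bound to an amide-type nitrogen. Within the data shown here, no measured pair shows this kind of exchange, so the expectation rests on the narrow spread of the three numbers. The step of a 1.0-fold lower number from compound 3 to compound 4 (0.02 log units; within the scatter) is expected to stay within the scatter. Compound 4 is estimated at 80000 nM, between 35000 nM and 160000 nM.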

Compound 4, half-maximal cytotoxic concentration: > 100000 nM
Compound 4 was reported as a limit; the forecaster's own chance of this, stated with the estimate: 35%; middle value at least 1.2-fold (0.09 log units) from the limit.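

In this assay, placing 4-aminophenyl instead of 2,4-difluorophenyl on the saturated chain carbon bound to an amide-type nitrogen gives an at least 1.1-fold higher number from compound 3 to compound 4 (0.07 log units; that floor lies within the scatter). Compound 4 gives > 100000 nM, which is a limit of the test and not a number. This first exchange at this place shows no fall in the number when an amine replaces the two fluorines, and a second compound now reaches the ceiling: the limit of > 100000 nM in this assay, at which 2 of the 4 values shown sit.

Going by these compounds, whether any group at this place can lower the number remains open. A carboxylic acid on the ring, or a longer chain in place of the ring, would test this.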